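Cyclohexyl in Place of Hydrogen: An Expected Large Gain

The source may hold more compounds than are shown below. What is called first, only, known or untested is meant among the compounds shown, and "the series" means these compounds.

Compound 1 `CC(C)(O)c1ccccc1CC[C@@H](SCC1(CC(=O)O)CC1)c1cccc(/C=C/c2nccs2)c1` is the starting point. In an assay on membranes from lung for inhibition of cysteinyl leukotriene receptor 1 (Cavia porcellus) (on this read-out higher numbers stand for weaker inhibition and lower numbers for stronger inhibition), compound 1 gives 381 nM; this is the only number shown for it, and it stands as the weaker of the two measured compounds. Compound 2 `CC(C)(O)c1ccccc1CC[C@@H](SCC1(CC(=O)O)CC1)c1cccc(/C=C/c2nc(C3CCCC3)cs2)c1` carries a cyclopentyl group on the same five-membered ring and in this assay compound 2 gives 1.4 nM; 0.8 nM (2 entries), far stronger than compound 1, with repeated entries that agree, (the several entries of compound 2 in this assay, 1.4 nM; 0.8 nM (2 entries)).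

Compound 3 `CC(C)(O)c1ccccc1CC[C@@H](SCC1(CC(=O)O)CC1)c1cccc(/C=C/c2nc(C3CCCCC3)cs2)c1` has not yet been measured. It differs from compound 1 by cyclohexyl in place of hydrogen on an aromatic carbon. The step of a 250-fold lower number from compound 1 to compound 3 (2.40 log units; beyond the scatter) is expected to be large and toward stronger inhibition, well beyond the scatter, because compound 2 reaches the several entries of compound 2 in this assay, 1.4 nM; 0.8 nM (2 entries) with a closely related ring at the same place. Compound 3 is therefore estimated at 1.5 nM, within a range from 0.4 nM to 6 nM.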

Compound 3, half-maximal inhibitory concentration: 2.1 nM
The estimate for compound 3 lay 1.4-fold (0.15 log units) below the measured number, within the range that was stated.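

Cyclohexyl in place of hydrogen, on the carbon next to the ring nitrogen, gives a 180-fold lower number from compound 1 to compound 3 (2.26 log units; beyond the scatter) in this assay. The large gain at this position is therefore not tied to the cyclopentyl group, since a six-membered non-aromatic ring of carbon only also delivers it. The number for compound 3, 2.1 nM, sits in the same low range as those of its five-membered relative: the several entries of compound 2 in this assay, 1.4 nM; 0.8 nM (2 entries)

All the groups shown at this position beyond hydrogen are rings of carbon only, so it remains open whether an open chain such as tert-butyl, an aromatic phenyl ring, or a cyclohexyl ring carrying an amine would serve as well. The compounds shown also cannot tell why these rings give so much lower a number than hydrogen.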